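The source may hold more compounds than are shown below. What is called first, only, known or untested is meant among the compounds shown, and "the series" means these compounds.

Measured so far:
- compound 1, `COc1ccc(-c2nc3ccccc3c(=O)[nH]2)cc1OCc1ccc(F)cc1F`: 44.6% in an ADME assay on cell membranes (microsomes) for inhibition of cytochrome P450 1A1 (Homo sapiens), read by fluorescence, tested at 10 uM; on this read-out higher numbers stand for more inhibition at the one concentration tested (going by the name of the read-out) and lower numbers for less inhibition
- compound 2, `COc1cc(-c2nc3ccccc3c(=O)[nH]2)ccc1OS(C)(=O)=O`: 32.6% in this assay

Compound 1 stands highest of the two numbers shown. Its nearest neighbour is compound 2, which lies lower by an amount that is beyond the usual scatter of this assay. Among the measured compounds shown here, no step between these two measured compounds has been worked out, so their two values are simply read side by side; the structures of the two differ in more than one place, and nothing can be tied to a single change.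

Compound 3, `C#CCOc1cc(-c2nc3ccccc3c(=O)[nH]2)ccc1OC`, has not yet been measured. It differs from compound 1 in one place: ethynyl in place of 2,4-difluorophenyl on a saturated chain carbon bound to an oxygen on an aromatic ring. A larger ring-bearing group at the chain carbon is replaced by a much smaller group carrying a triple bond. For the measured compounds named here, with no measured step of this kind on hand, the direction can only be guessed. The expectation for compound 3 is a modest fall in inhibition, with the estimated step of a number 14.6 percentage points lower from compound 1 to compound 3 (beyond the scatter) roughly at the edge of the scatter. Compound 3 is therefore estimated at 30%, within a range from 10% to 52%.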

Compound 3, a percentage reported as inhibition, at one concentration (the size of the read-out at that concentration, not a potency): 54.4%
Compound 3: middle estimate off by 24.4 percentage points, on the low side; measured number outside the range, above it.
By their numbers in this assay, from the lowest: compound 2; then compounds 1 and 3 (each within the scatter of the next).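

At this position, on a saturated chain carbon bound to an oxygen on an aromatic ring, 2,4-difluorophenyl, with its 8 heavy atoms and six-membered aromatic ring, was replaced by ethynyl, with 2 heavy atoms and no ring, and this assay gives a number 9.8 percentage points higher from compound 1 to compound 3 (within the scatter). For this one pair, then, a far smaller group without a ring leaves the two compounds indistinguishable in this read-out, so the 2,4-difluorophenyl ring is not needed for inhibition on the scaffold of compound 1. Nothing measured here offers an explanation of why the two compounds read alike.

A single pair cannot show whether the inhibition in this assay stays level with other groups at the same place, such as an amine, a carboxylic acid or a longer chain. It also leaves open whether the triple bond itself matters, a question that a propyl group, the saturated counterpart of propargyl, would help to answer when set beside compound 3 in this assay.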